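The source may hold more compounds than are shown below. What is called first, only, known or untested is meant among the compounds shown, and "the series" means these compounds.

In a functional assay on HL-60 cells (Homo sapiens) for antiproliferative activity, read by MTT assay, with a stated time of 72 h (a lower number here means a stronger inhibitor, a higher number a weaker inhibitor), compound 2 `CCOc1ccc(-c2ncnn2-c2cc(OC)c(OC)c(OC)c2)cc1Cl` gives 3 nM, the lower of the two actual numbers in this small set, while compound 3 `CCOc1ccc(-c2ncnn2-c2cc(OC)c(OC)c(OC)c2)cc1` gives 20 nM. Compound 1 `COc1cc(-c2ncnn2-c2cccc(N)c2)cc(OC)c1OC` reports only a limit, > 10000 nM. Compound 4 `COc1cc(-n2ncnc2-c2cccc(Cl)c2)cc(OC)c1OC` differs from compound 2 by hydrogen in place of ethoxy on an aromatic carbon, with hydrogen in place of ethoxy on an aromatic carbon. The closest measured change is a 6.7-fold higher number from compound 2 to compound 3 (0.82 log units; beyond the scatter), where hydrogen replaces chloro on the same ring and the ethoxy stays. Within the data shown here, no measured step removes the ethoxy itself, so this is only a rough guide. A rise of similar or larger size is expected, and the estimated change is a 67-fold higher number from compound 2 to compound 4 (1.82 log units; beyond the scatter). Compound 4 is expected near 200 nM, within an estimated range of 30 nM to 2000 nM.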

Compound 4, half-maximal inhibitory concentration: > 10000 nM
Compound 4: only a limit was reported; the forecaster's own chance of this, stated with the estimate: 10%; at least 50-fold (1.69 log units) between middle value and limit.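

In this assay, hydrogen in place of ethoxy gives an at least 3300-fold higher number from compound 2 to compound 4 (3.52 log units; beyond the scatter), while hydrogen in place of chloro gave only a 6.7-fold higher number from compound 2 to compound 3 (0.82 log units; beyond the scatter). Within this small set, the ethoxy therefore matters far more than the chloro, and losing it leaves no measurable potency in this assay. The value for compound 4 is a limit, so the full size of the step stays unknown: the limit of > 10000 nM in this assay, at which 2 of the 4 values shown sit.

With only ethoxy and hydrogen shown at this position, the effect of a methoxy or a longer chain such as propoxy remains open.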